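Shortening a side chain on the shared core

The source may report more compounds than this note shows. Statements on the series, on what has been measured and on what is new or still open speak of the compounds shown alone.

Measured so far:
- compound 1, `CCCc1c(OCc2ccc(/C=C/C(=O)O)cc2)ccc(C(C)=O)c1O`: 570 nM
- compound 2, `C=C(C)Cc1c(OCc2ccc(C(=O)O)cc2OC)ccc(C(C)=O)c1O`: 1640 nM

Of the compounds shown here, two have been tested in an assay on isolated protein with cysteinyl leukotriene receptor 1 (Cavia porcellus) as the target; a higher number here means a weaker inhibitor, a lower number a stronger inhibitor. Compound 1 gives 570 nM, while compound 2 gives 1640 nM, the higher of the two numbers, and the gap to compound 1 is beyond the usual scatter. These two differ in more than one place, so no single change can be credited for the gap.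

Compound 3, `COc1cc(C(=O)O)ccc1COc1ccc(C(C)=O)c(O)c1C`, has not yet been measured. It differs from compound 2 in one place: hydrogen in place of 1-methylethenyl on a saturated chain carbon bound to an aromatic carbon. In other words, the 2-methylprop-2-en-1-yl group becomes a methyl group.

Among the compounds with values here, with no measured pair isolating this change, the expectation rests on compound 2 alone. Removing this carbon chain is expected to raise the number somewhat in this assay, so the step is estimated as a 2.4-fold higher number from compound 2 to compound 3 (0.39 log units; beyond the scatter). Compound 3 is therefore estimated at 4000 nM, with a plausible range from 1500 nM to 12000 nM.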

Compound 3, antagonist equilibrium constant: 850 nM
Estimate against measurement, compound 3: 4.7-fold (0.67 log units) above; the whole stated range lies above it.
By their numbers in this assay, from the lowest: compounds 1, 3 and 2 (each within the scatter of the next, the first and the last beyond it).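

In this assay, within the data shown here, cutting the 2-methylprop-2-en-1-yl group back to methyl gives a 1.9-fold lower number from compound 2 to compound 3 (0.29 log units; within the scatter) and is the first change here that can be read on its own. On this pair, the position does not need the larger carbon group to keep the number in the same range, and losing the double bond and the 1-methylethenyl branch leaves no effect beyond the scatter. No measurement at hand explains this result.

As far as these compounds go, it remains open whether an ethyl group, a longer chain such as hexyl, or an amine in place of the methyl group would also stay in this range. Compound 1 differs from compound 3 in more than one place, so it cannot settle this question.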